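The source may report more compounds than this note shows. Statements on the series, on what has been measured and on what is new or still open speak of the compounds shown alone.

Of the compounds shown here, three share one core and have been tested in a functional assay on HEp-2 cells (Homo sapiens) for antiproliferative activity, read by MTT assay, with a stated time of 72 h; on this read-out higher numbers stand for weaker inhibition and lower numbers for stronger inhibition. Compound 1 `O=c1c(CSC(=S)N2CCCC2)coc2ccccc12` is the simplest of them; in this assay compound 1 gives 3600 nM. Compound 2 `Cc1ccc2c(=O)c(CSC(=S)N3CCCC3)coc2c1` differs from compound 1 by methyl in place of hydrogen on an aromatic carbon, and in this assay compound 2 gives 3600 nM. The step of no change at the digits printed from compound 1 to compound 2 (within the scatter) is therefore one that repeated measurements of this kind could produce on their own. Compound 3 `O=c1c(CSC(=S)N2CCOCC2)coc2ccccc12` differs from compound 1 by morpholin-4-yl in place of pyrrolidin-1-yl on a thiocarbonyl carbon; in this assay compound 3 gives 4400 nM. The step of a 1.2-fold higher number from compound 1 to compound 3 (0.09 log units; within the scatter) is likewise no larger than the usual scatter, so none of the three numbers can be set above or below the others.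

Compound 4 `Cc1ccc2c(=O)c(CSC(=S)N3CCOCC3)coc2c1` has not yet been measured in this assay. It differs from compound 3 by methyl in place of hydrogen on an aromatic carbon. Within the data shown here, this is the same change as the one made from compound 1 to compound 2, at a place described in exactly the same words, only on a core that differs from the core of compound 1 in the way already described for compound 3. Because that earlier step, no change at the digits printed from compound 1 to compound 2 (within the scatter), stayed within the scatter, the step from compound 3 to compound 4 is expected to be no change at the digits printed from compound 3 to compound 4 (within the scatter). On that basis compound 4 is estimated to give 4400 nM in this assay, with a likely range from 2500 nM to 8000 nM.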

Compound 4, half-maximal inhibitory concentration: 4000 nM
For compound 4 the middle estimate is 1.1-fold (0.04 log units) above the measured one; the range from low to high includes it.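

In this assay, methyl in place of hydrogen on an aromatic carbon gives a 1.1-fold lower number from compound 3 to compound 4 (0.04 log units; within the scatter), and this step can be set against the one seen earlier on the core of compound 1: the same change on two cores in this assay, no change at the digits printed (within the scatter) from compound 1 to compound 2 and a 1.1-fold lower number (0.04 log units; within the scatter) from compound 3 to compound 4, 1.1-fold (0.04 log units) apart, within the scatter of two such steps. Morpholin-4-yl in place of pyrrolidin-1-yl on the thiocarbonyl carbon gives a 1.1-fold higher number from compound 2 to compound 4 (0.05 log units; within the scatter), and this too can be set against its earlier counterpart: the same change on two cores in this assay, a 1.2-fold higher number (0.09 log units; within the scatter) from compound 1 to compound 3 and a 1.1-fold higher number (0.05 log units; within the scatter) from compound 2 to compound 4, 1.1-fold (0.04 log units) apart, within the scatter of two such steps. Across these four compounds, then, neither change moves the number beyond the scatter on either core, and the two steps of each pair agree. This does not show that a real effect carries from one core to the other.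

The compounds shown leave open whether other groups would move the number, such as chlorine or methoxy in place of the methyl, or a piperazin-1-yl or diethylamino group in place of the morpholin-4-yl. Whether a step beyond the scatter, if such a group produced one, would also hold from one core to the other is a question these four numbers cannot answer.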